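The source may report more compounds than this note shows. Statements on the series, on what has been measured and on what is new or still open speak of the compounds shown alone.

Of the compounds shown here, two have been measured so far in a functional assay on RBL cells for antagonist activity at C-X-C chemokine receptor type 1 (Homo sapiens), read by fluorescence and calcium flux, with a stated time of 30 min; on this read-out lower numbers stand for stronger inhibition and higher numbers for weaker inhibition. Compound 1, with the structure `O=C(Nc1ccc(F)cc1)c1cnc(N(Cc2ccccc2)Cc2ccc(B(O)O)cn2)nc1`, gives in this assay 7 nM. Compound 2, with the structure `CN(Cc1ccc(B(O)O)cc1)c1ncc(C(=O)Nc2ccc(F)cc2)cn1`, gives in this assay 681 nM. Of these two numbers, compound 2 has the highest, and its nearest neighbour, compound 1, shows a far lower number, a gap that lies well beyond the usual scatter of such measurements. No single-point comparison exists between them, since they differ in more than one place.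

The next compound, compound 3, has the structure `CN(Cc1ccc(B(O)O)cn1)c1ncc(C(=O)Nc2ccc(F)cc2)cn1`. It is obtained from compound 2 by a single change: a group of 9 heavy atoms (5 carbon, 1 boron, 1 nitrogen, 2 oxygen; one six-membered aromatic ring with 1 hetero atom) in place of a group of 9 heavy atoms (6 carbon, 1 boron, 2 oxygen; one six-membered aromatic ring of carbon only), on a saturated chain carbon bound to a nitrogen on an aromatic ring. The group that enters is the same boron-bearing ring that compound 1 carries, but compound 1 also bears a different second group on its chain nitrogen, so the two measured values cannot be split into one part for each change.

With that in mind, the step from compound 2 to compound 3 is expected to be a 4.5-fold lower number from compound 2 to compound 3 (0.66 log units; beyond the scatter), toward a lower number. Compound 3 is therefore estimated at 150 nM, within a range from 30 nM to 700 nM.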

Compound 3, half-maximal inhibitory concentration: 1700 nM
Beside the measured number, compound 3's estimate is 11-fold (1.05 log units) below it; the whole stated range lies below it.
By their numbers in this assay, from the lowest: compound 1; then compound 2; then compound 3.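

In this assay, exchanging the carbon-only six-membered aromatic ring for the six-membered aromatic ring with 1 hetero atom, while the boron stays on the ring, gives a 2.5-fold higher number from compound 2 to compound 3 (0.40 log units; beyond the scatter) and so moves the number the wrong way for inhibition. This is a modest step, but it is beyond the scatter, and it shows that this ring alone does not carry the low number of compound 1. With that same ring in both compounds, hydrogen in place of phenyl on the saturated chain carbon bound to a nitrogen on an aromatic ring gives the far larger a 240-fold higher number from compound 1 to compound 3 (2.39 log units; beyond the scatter), so in this pair the strong inhibition goes with the phenyl, and no measurement here says why either step occurs.

The compounds shown leave open whether the carbon-only ring would also give a lower number than the ring with 1 hetero atom when the phenyl is present. They also leave open whether a longer chain or a cyclohexyl group on that chain carbon could match phenyl, and whether a carboxylic acid could take the place of the boron-bearing group.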